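Removing the trifluoromethyl from a hydroxamic acid benzyl lactam

This account rests on a few compounds, and the source may have more. Where it says the series, first, only, none or still open, it means among the compounds named here.

Two compounds share a hydroxamic acid side chain on an unsaturated lactam core and have been measured in a functional assay on ACHN cells (Homo sapiens) for antiproliferative activity; on this read-out lower numbers stand for stronger inhibition of growth and higher numbers for weaker inhibition of growth. Compound 1 `O=C(CCC1=CCN(Cc2ccc(C(F)(F)F)cc2)C1=O)NO` gives 4290 nM. Compound 2 `COc1ccc(CCCN2CC=C(CCC(=O)NO)C2=O)cc1`, which carries a methoxyphenyl group on a three-carbon chain in place of the benzyl group, gives 4750 nM in this assay. The two numbers sit within the scatter of each other, so compound 1 stands level with compound 2 and neither can be called the more potent. Compound 3 `O=C(CCC1=CCN(Cc2ccccc2)C1=O)NO` has not yet been measured. It differs from compound 1 by hydrogen in place of trifluoromethyl on an aromatic carbon. For the measured compounds named here, no measured pair shows what such a change does here, so the expected step from compound 1 to compound 3 is a 1.3-fold higher number from compound 1 to compound 3 (0.11 log units; within the scatter), a shift not expected to exceed the scatter. Compound 3 is therefore estimated at 5500 nM in this assay, with a range from 2200 nM to 14000 nM.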

Compound 3, concentration for 50% growth inhibition: 1080 nM
The estimate for compound 3 lay 5.1-fold (0.71 log units) above the measured number; the whole stated range lies above it.
By their numbers in this assay, from the lowest: compound 3; then compounds 1 and 2 (each within the scatter of the next).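

For the compounds shown here, the step gives the first reading of this position in this assay: hydrogen in place of trifluoromethyl on an aromatic carbon, para to a large group, gives a 4.0-fold lower number from compound 1 to compound 3 (0.60 log units; beyond the scatter) on the benzyl lactam. The trifluoromethyl is therefore not required for growth inhibition in this series, and the unsubstituted benzyl compound does better here, something compound 1 and compound 2 could not show, as they differ in more than one place and stand level. No measurement at hand accounts for the size of this step.

From the compounds shown here alone, it remains open whether any group at this carbon raises the number or only trifluoromethyl does, which a single fluorine, a nitrile or an amine there would test. The compounds shown also leave open whether a longer chain between the lactam nitrogen and the unsubstituted phenyl ring would keep the lower number.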